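What a tert-butyl group may do to compound 3

The source may report more compounds than this note shows. Statements on the series, on what has been measured and on what is new or still open speak of the compounds shown alone.

Going by the values given here, in a functional assay on HT-29 cells (Homo sapiens) for antiproliferative activity, read by sulforhodamine B assay, with a stated time of 48 h (a higher number here means a weaker inhibitor, a lower number a stronger inhibitor), compound 3 `O=C1NCCN1c1ccc(S(=O)(=O)Nc2ccccc2)cc1` gives 280 nM as the only true number so far. Compound 1 `O=C1NCCN1c1ccc(S(=O)(=O)Nc2ccc(C3CCCCC3)cc2)cc1` reads > 1000 nM which is a limit and not a number. Compound 2 `CCCCCCCc1ccc(NS(=O)(=O)c2ccc(N3CCNC3=O)cc2)cc1` reads > 1000 nM which is likewise a limit. The change tert-butyl in place of hydrogen on an aromatic carbon turns compound 3 into compound 4 `CC(C)(C)c1ccc(NS(=O)(=O)c2ccc(N3CCNC3=O)cc2)cc1` by putting tert-butyl in place of hydrogen on an aromatic carbon. Among the compounds with values here, two measured steps bear on this: hydrogen in place of cyclohexyl gave an at least 3.5-fold lower number from compound 1 to compound 3 (0.55 log units; beyond the scatter) and hydrogen in place of heptyl gave an at least 3.5-fold lower number from compound 2 to compound 3 (0.55 log units; beyond the scatter) so both times the number fell when the group left. Adding tert-butyl should therefore work the other way, with an estimated 2.9-fold higher number from compound 3 to compound 4 (0.46 log units; beyond the scatter) expected in this assay for this change. Compound 4 is expected at 800 nM with 280 nM to 2300 nM as its likely range.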

Compound 4, half-maximal inhibitory concentration: > 1000 nM
Compound 4: no number, only a limit; the forecaster's own chance of this, stated with the estimate: 40%; at least 1.2-fold (0.09 log units) between middle value and limit.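

Tert-butyl in place of hydrogen on an aromatic carbon gives an at least 3.5-fold higher number from compound 3 to compound 4 (0.55 log units; beyond the scatter) in this assay and so shows that at this position, para to a large group, the number can rise without a ring as in cyclohexyl or a long chain as in heptyl. Compound 4 gives > 1000 nM and this is a limit, not a number. The steps among compound 1, compound 2 and compound 4 cannot be read, because all three stop at the same limit: the limit of > 1000 nM in this assay, at which 3 of the 4 values shown sit.

From the compounds shown here alone, whether a methyl group, an amine or a carboxylic acid at this position would keep the number of compound 3 stays open.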